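A Dichlorophenyl Urea Anticipated from Two Measured Analogues

This account rests on a few compounds, and the source may have more. Where it says the series, first, only, none or still open, it means among the compounds named here.

Measured compounds:
compound 1, `COc1cc2cc(Oc3ccc(NC(=O)Nc4ccccc4)cc3)c(C)nc2cc1OC`, 55.3%
compound 2, `COc1cc2cc(Oc3ccc(NC(=O)Nc4ccc(C)cc4)cc3)c(C)nc2cc1OC`, 101%

Of the compounds shown here, two have so far been tested in a functional assay on CCRF-CEM cells (Homo sapiens) for inhibition, read by sulforhodamine B assay, with a stated time of 48 h, tested at 10 uM; on this read-out higher numbers stand for a weaker effect at the one concentration tested and lower numbers for a stronger effect. Compound 1 gives 55.3%, the lowest of the two numbers; compound 2 gives 101%. Among the compounds with values here, the single step between them, a number 45.7 percentage points higher from compound 1 to compound 2 (beyond the scatter), is a large weakening that comes with a methyl in place of hydrogen on an aromatic carbon.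

Compound 3, `COc1cc2cc(Oc3ccc(NC(=O)Nc4ccc(Cl)c(Cl)c4)cc3)c(C)nc2cc1OC`, has not yet been measured. It differs from compound 1 in one place: 3,4-dichlorophenyl in place of phenyl on an amide-type nitrogen. Within the data shown here, only the step between compound 1 and compound 2 bears on this change, as it too adds substituents to the phenyl on the amide-type nitrogen. Because a number 45.7 percentage points higher from compound 1 to compound 2 (beyond the scatter) was large, a rise is expected here as well, although two chlorines are not a methyl and the range is kept wide. Compound 3 is therefore expected to give 85%, between 50% and 110%. That estimate means an expected step of a number 29.7 percentage points higher from compound 1 to compound 3 (beyond the scatter), upward and beyond the scatter.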

Compound 3, a percentage reported as activity, at one concentration (the size of the read-out at that concentration, not a potency): 13.3%
For compound 3 the middle estimate is 71.7 percentage points above the measured one; the whole stated range lies above it.
By their numbers in this assay, from the lowest: compound 3; then compound 1; then compound 2.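

In this assay, the phenyl on the amide-type nitrogen proves not to respond in a single direction when substituents are added: 3,4-dichlorophenyl in place of phenyl brings a number 42 percentage points lower from compound 1 to compound 3 (beyond the scatter) and so a stronger effect, while 4-methylphenyl in place of phenyl had brought a number 45.7 percentage points higher from compound 1 to compound 2 (beyond the scatter) and a weaker one. The choice of substituent at this position therefore decides the direction of the change, and the exchange of 4-methylphenyl for 3,4-dichlorophenyl spans a number 87.7 percentage points lower from compound 2 to compound 3 (beyond the scatter) in the same read-out.

The compounds shown leave open whether a single chlorine would suffice or both are needed, and how a methoxy or trifluoromethyl group would fare at this position. Why the two substituted rings diverge so sharply remains unexplained, as no measurement at hand speaks to it.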